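The compounds below may be only part of what the source reports. "The series", "measured", "known", "first", "only" and "open" are said of these compounds alone.

Notes on the series. Compound 1 `O=c1cc(CNc2nc(-c3cc4cc(Br)cc(Br)c4oc3=O)cs2)c2cc(Cl)ccc2[nH]1` in a functional assay on the whole organism for inhibition, with Rattus norvegicus as the target, read by paw edema, in the formalin test, with a stated time of 12 h, at a dose of 100 mg/kg by the intraperitoneal route (a lower number here means less inhibition, a higher number more inhibition at the dose given (going by the name of the read-out)), gives 14.4%, the lowest of the three numbers in hand. Compound 2 `O=c1cc(CNc2nc(-c3cc4cc(Br)cc(Br)c4oc3=O)cs2)c2ccc(Cl)cc2[nH]1` in this assay gives 18.7%, and compound 3 `O=c1cc(CNc2nc(-c3cc4cc(Br)ccc4oc3=O)cs2)c2ccc(Cl)cc2[nH]1` in this assay gives 23.2%; both stand within the scatter of compound 1. Compound 4 `O=c1cc(CNc2nc(-c3cc4cc(Br)ccc4oc3=O)cs2)c2cc(Cl)ccc2[nH]1` differs from compound 1 by hydrogen in place of bromo on an aromatic carbon. Within the data shown here, the one measured step of the same kind is a number 4.5 percentage points higher from compound 2 to compound 3 (within the scatter), within the scatter, on the pair sharing the core of compound 2. On that basis the step in this assay to compound 4 is expected to be small, a number 3.6 percentage points higher from compound 1 to compound 4 (within the scatter), with nothing beyond the scatter. Compound 4 is therefore expected to give 18% in this assay, within a range of 8% to 30%.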

Compound 4, a percentage reported as inhibition, in the whole organism at one dose (the size of the read-out at that dose, not a potency): 15.6%
Beside the measured number, compound 4's estimate is 2.4 percentage points above it; the measured number falls inside the stated range.
By their numbers in this assay, from the lowest: compounds 1, 4, 2 and 3 (each within the scatter of the next).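

Hydrogen in place of bromo, on the aromatic carbon ortho to a fused ring, can now be read on a second core in this assay, with a number 1.2 percentage points higher from compound 1 to compound 4 (within the scatter). At this position, the read-out does not separate bromo from hydrogen on either core, and the two steps agree: the same change on two cores in this assay, a number 4.5 percentage points higher (within the scatter) from compound 2 to compound 3 and a number 1.2 percentage points higher (within the scatter) from compound 1 to compound 4, 3.3 percentage points apart, within the scatter of two such steps

The compounds shown leave open whether an amine or a carboxylic acid on this aromatic carbon would move the number beyond the scatter. With a single dose, they also leave potency open.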